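Hydroxyphenyl position shift on the shared core

A few compounds are considered here, and "the series" means these few. Any claim that something is new, unique, unknown or untested is made for them only; others in the source may bear on it.

Measured compounds:
compound 1 `Brc1ccccc1CSc1nnc(-c2ccncc2)n1-c1ccccc1`, 16100 nM in a functional assay on MCF7 cells (Homo sapiens) for inhibition, read by MTT assay, with a stated time of 48 h; on this read-out lower numbers stand for stronger inhibition and higher numbers for weaker inhibition
compound 2 `Brc1cccc(CSc2nnc(-c3ccncc3)n2-c2ccccc2)c1`, 10000 nM in this assay
compound 3 `O=C(CSc1nnc(-c2ccncc2)n1-c1ccccc1)N/N=C/c1ccc(O)cc1`, a limit of > 50000 nM in this assay

Compound 3 stands at the limit of the assay rather than at a number, at the limit of > 50000 nM in this assay, at which 1 of the 3 values shown sits. Within the data shown here, compound 1 and compound 2 are the only two with measured numbers.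

Compound 4 `O=C(CSc1nnc(-c2ccncc2)n1-c1ccccc1)N/N=C/c1ccccc1O` is not yet measured. It differs from compound 3 as follows: 2-hydroxyphenyl in place of 4-hydroxyphenyl on a carbon with a double bond to nitrogen.

Among the measured compounds shown here, the only measured step is a 1.6-fold lower number from compound 1 to compound 2 (0.21 log units; within the scatter), which concerns a bromophenyl on a saturated chain carbon bound to a sulfur and not the hydrazone end changed here. It gives no direct guide for the shift from compound 3 to compound 4, and it was itself within the scatter. For the measured compounds named here, with compound 3 at the limit and no measured step on this part of the molecule, no step beyond the scatter is expected.

Compound 4 is therefore expected to sit near the limit as well, with the step that the limit leaves unreadable from compound 3 to compound 4 estimated as no real change. The estimate for compound 4 in this assay is 60000 nM, between 20000 nM and 150000 nM.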

Compound 4, half-maximal inhibitory concentration: 10000 nM
Beside the measured number, compound 4's estimate is 6.0-fold (0.78 log units) above it; measured number outside the range, below it.
By their numbers in this assay, from the lowest: compounds 2, 4 and 1 (each within the scatter of the next). At a limit, above all of these: compound 3.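

With the same atoms joined differently, 2-hydroxyphenyl in place of 4-hydroxyphenyl on the carbon with a double bond to nitrogen gives an at least 5.0-fold lower number from compound 3 to compound 4 (0.69 log units; beyond the scatter) in this assay. The value of compound 3 is a limit and not a number, so this step gives only the smallest size the change can have: the limit of > 50000 nM in this assay, at which 1 of the 4 values shown sits. The bromophenyl shift gave a 1.6-fold lower number from compound 1 to compound 2 (0.21 log units; within the scatter), so the hydrazone end is the one place shown where moving a substituent around the ring changes the read-out beyond the scatter.

Open, as far as these compounds go, is whether a 2-methoxyphenyl or a 2-aminophenyl on this carbon would keep the number of compound 4, and where a 3-hydroxyphenyl would fall. Among these compounds, also open is how much of compound 4's number depends on the 2-hydroxyphenyl alone, since only this one pair reports on that end.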